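A few compounds are considered here, and "the series" means these few. Any claim that something is new, unique, unknown or untested is made for them only; others in the source may bear on it.

Compound 1 `CNC(=O)/C=C/c1ccncc1-c1ccc2cc[nH]c2c1` and compound 2 `O=C(/C=C/c1ccncc1-c1ccc2cc[nH]c2c1)N1CCOCC1` share one core, while compound 3 `O=C(CCc1ccncc1-c1ccc2ccccc2c1)N1CCOCC1` carries another; the difference between the two cores is not broken down here. In a functional assay on KB cells (Homo sapiens) for inhibition, read by sulforhodamine B assay, with a stated time of 72 h (on this read-out lower numbers stand for stronger inhibition of growth and higher numbers for weaker inhibition of growth), compound 1 gives > 10000 nM, which is a limit of the assay rather than a number. Compound 2 likewise reaches only a limit in this assay, at > 10000 nM. Compound 3 too sits at a limit in this assay, > 10000 nM. The change from compound 2 to compound 1 is methylamino in place of morpholin-4-yl on a carbonyl carbon, and its step is a step that the two limits leave unreadable from compound 2 to compound 1. From compound 3 to compound 4 `CNC(=O)CCc1ccncc1-c1ccc2ccccc2c1` the same kind of change is made, (methylamino in place of morpholin-4-yl on a carbonyl carbon), here on a carbonyl carbon whose other neighbour is a saturated chain carbon rather than a double-bonded chain carbon. Because (the limit of > 10000 nM in this assay, at which 3 of the 3 values shown sit), compound 4 is expected to give a step that the limit leaves unreadable from compound 3 to compound 4. Compound 4 is therefore estimated at 20000 nM, most likely reported again only as a limit.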

Compound 4, concentration for 50% growth inhibition: > 10000 nM
Compound 4 gave a limit, no number; the forecaster's own chance of this, stated with the estimate: 85%; the middle value does not contradict the limit.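

For the compounds shown here, compound 3 and compound 4 both give only a limit, not a number, and no step between them can be read. The compounds shown leave open whether methylamino in place of morpholin-4-yl changes growth inhibition at all: the limit of > 10000 nM in this assay, at which 4 of the 4 values shown sit.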